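The compounds below may be only part of what the source reports. "The series", "measured", "known", "first", "only" and "open" are said of these compounds alone.

Compounds measured so far:
- compound 1, `COC(=O)[C@H]1c2cc(/C=C/C(=O)NCCCCNC(=N)N)ccc2O[C@@H]1c1ccc(O)cc1`: 2160000 nM
- compound 2, `N=C(N)NCCCCNC(=O)/C=C/c1ccc2c(c1)[C@H](C(=O)NCCCCNC(=N)N)[C@@H](c1ccc(O)cc1)O2`: 310000 nM
- compound 3, `N=C(N)NCCCCNC(=O)/C=C/c1ccc2c(c1)[C@H](C(=O)NCCCCNC(=N)N)[C@H](c1ccc(O)cc1)O2`: 420000 nM

All three were tested in an assay on isolated protein (Salivary gland) for displacement of a labelled ligand from Alpha-1A adrenergic receptor (Rattus norvegicus); a lower number here means a stronger inhibitor, a higher number a weaker inhibitor. Among them compound 2 gives the lowest number, and compound 3 stands next to it at a 1.4-fold higher number from compound 2 to compound 3 (0.13 log units; within the scatter), so the two cannot be told apart; the only difference between them is a single stereocentre, as shown by the fact that one of compounds 2 and 3 is drawn with a defined configuration and the other without, at the place where they differ. Among the measured compounds shown here, compound 1 stands furthest away, at a 7.0-fold lower number from compound 1 to compound 2 (0.84 log units; beyond the scatter), which is the one step beyond the scatter: replacing the methyl ester on the ring carbonyl of compound 1 with the guanidine-bearing chain of compound 2 lowers the number.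

Compound 4, `N=C(N)NCCCCNC(=O)[C@H]1c2cc(/C=C/C(=O)O)ccc2O[C@@H]1c1ccc(O)cc1`, is the untested member. Compared with compound 2 it keeps that chain on the ring carbonyl but changes the other end: one oxygen atom in place of a group of 9 heavy atoms (5 carbon, 4 nitrogen; no ring), on a carbonyl carbon, turning the second amide into a carboxylic acid. For the measured compounds named here, the only measured step that bears on losing such a chain is a 7.0-fold lower number from compound 1 to compound 2 (0.84 log units; beyond the scatter), read in reverse. On that basis the number for compound 4 is expected to rise by a 6.5-fold higher number from compound 2 to compound 4 (0.81 log units; beyond the scatter), ending weaker than compound 2. Compound 4 is therefore estimated at 2000000 nM, within a range of 600000 nM to 6000000 nM.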

Compound 4, half-maximal inhibitory concentration: > 100000000 nM
Compound 4: no number, only a limit (the forecaster's own chance of this, stated with the estimate: 30%); at least 50-fold (1.69 log units) between middle value and limit.
By their numbers in this assay, from the lowest: compounds 2 and 3 (each within the scatter of the next); then compound 1. At a limit, above all of these: compound 4.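

In this assay compound 4 gives > 100000000 nM as a limit of the assay, not a number. Among the compounds shown here, this is the first look at the chain of 9 heavy atoms on the carbonyl carbon whose other neighbour is a double-bonded chain carbon, and putting hydroxy in its place produces a large change, an at least 320-fold higher number from compound 2 to compound 4 (2.50 log units; beyond the scatter), so this place is far from indifferent to what it carries. The earlier compounds shown here showed only a modest change at the other carbonyl carbon, a 7.0-fold lower number from compound 1 to compound 2 (0.84 log units; beyond the scatter), and a change of one stereocentre, a 1.4-fold higher number from compound 2 to compound 3 (0.13 log units; within the scatter), that stays within the scatter.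

One swap cannot separate what the departing chain contributes from what the entering hydroxy contributes, and a plain primary amide or a methyl ester at this same carbonyl carbon, or a longer chain ending in the same guanidine, would help to pull those two apart. Going by these compounds, the true size of the change also remains open, since one end of it is a limit and the number for compound 4 could lie anywhere past it.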